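Tolerated concentration notes: from compound 2 to compound 4

The compounds below may be only part of what the source reports. "The series", "measured", "known", "first", "only" and "open" are said of these compounds alone.

Three compounds of the series have a number in an ADME assay on PBMC cells (Homo sapiens) for cytotoxicity; a lower number here means that less compound is tolerated, a higher number that more compound is tolerated. Compound 2 `CC(CCNC(=O)c1c(Cl)cncc1Cl)N1CCC(C(Oc2cccc(C(F)(F)F)c2)c2ccc(C(F)(F)F)cc2)CC1` gives 7000 nM in this assay, the second highest of the three numbers. Compound 1 `Cc1cccc(OC(c2ccc(Br)cc2)C2CCN(C(C)CCNC(=O)c3c(Cl)cncc3Cl)CC2)n1` gives 6500 nM, and the two values lie within the scatter of each other, so no order between compound 1 and compound 2 is claimed. Going by the values given here, compound 3 `CC(CCNC(=O)c1c(Cl)cncc1Cl)N1CCC(C(=O)c2ccc(Br)cc2)CC1` gives 189000 nM, a far higher number than compound 2, meaning much more of compound 3 is tolerated; no single-place step between these two compounds is available, so only their two values are recorded.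

Compound 4 `CC(CCNC(=O)c1c(Cl)cncc1Cl)N1CCC(C(Oc2ncccc2Cl)c2ccc(C(F)(F)F)cc2)CC1` has not yet been measured in this assay. Relative to compound 2 the change is 3-chloropyridin-2-yl in place of 3-(trifluoromethyl)phenyl on an oxygen on a saturated carbon. Among the compounds with values here, no measured pair carries this kind of change, so there is no step from which to read its size.

Given that compound 2 gives 7000 nM and that compound 1, with a different pair of aryl groups, lies within the scatter of it, the expectation for compound 4 is a step of a 1.4-fold higher number from compound 2 to compound 4 (0.15 log units; within the scatter) that is small, upward if anything, and may well not exceed the scatter. Compound 4 is therefore estimated at 10000 nM in this assay, with a range from 4000 nM to 30000 nM.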

Compound 4, half-maximal cytotoxic concentration: 16700 nM
Compound 4: the middle estimate sits 1.7-fold (0.22 log units) below what was measured; the range from low to high includes it.
By their numbers in this assay, from the lowest: compounds 1 and 2 (each within the scatter of the next); then compound 4; then compound 3.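

In this assay, going by these compounds alone, this is the first change that can be read at a single place, and it gives a 2.4-fold higher number from compound 2 to compound 4 (0.38 log units; beyond the scatter): a modest step, but one showing that the group on the oxygen on a saturated carbon can shift the tolerated concentration, which the earlier values alone could not show. Within this one pair, more compound is tolerated with 3-chloropyridin-2-yl than with 3-(trifluoromethyl)phenyl, so this exchange moves the number upward, though one pair sets no trend. No measurement at hand accounts for the step.

From the compounds shown here alone, the exchange alters several things at once, bringing in a ring nitrogen and a chlorine and removing the trifluoromethyl, so the share of each in the step stays open, and a plain phenyl or an unsubstituted pyridine ring at this place would be needed to separate them. Also open, going by these compounds, are whether the same exchange gives a similar step with a different aryl group on the saturated carbon, and how an amine or a carboxylic acid on this ring would read in this assay.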